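The source may report more compounds than this note shows. Statements on the series, on what has been measured and on what is new or still open speak of the compounds shown alone.

Measured so far in a functional assay on KB 3-1 cells (Homo sapiens) for antiproliferative activity, read by WST assay, with a stated time of 5 days (a lower number here means a stronger inhibitor, a higher number a weaker inhibitor), are two compounds:

Compound 1 `COc1cc(O)c2c(c1O)C/C(C)=C\CC[C@@]1(C)O[C@@H]1C2=O` gives 10000 nM
Compound 2 `COc1cc(O)c2c(c1O)C/C(CO)=C\CC[C@@]1(C)O[C@@H]1C2=O` gives 59000 nM

Compound 2 holds the higher number of the two at 59000 nM and is the weaker inhibitor, beyond the scatter. Compound 3 `COc1cc(O)c2c(c1O)C/C(C(OC(C)=O)OC(C)=O)=C\CC[C@@]1(C)O[C@@H]1C2=O` has diacetoxymethyl in place of hydroxymethyl on a double-bonded ring carbon and has not yet been measured. Among the measured compounds shown here, one step bears on this change. Going a 5.9-fold higher number from compound 1 to compound 2 (0.77 log units; beyond the scatter) is modest, and it came with hydroxy in place of hydrogen on the saturated chain carbon. For the measured compounds named here, compound 3 no longer carries that hydroxy, yet no measured compound carries diacetoxymethyl. A modest move towards lower numbers in this assay is therefore expected, though with wide uncertainty. The expected change is a 2.4-fold lower number from compound 2 to compound 3 (0.37 log units; beyond the scatter) as a rough guide. In this assay compound 3 is estimated at 25000 nM with a range of 6000 nM to 90000 nM expected.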

Compound 3, half-maximal inhibitory concentration: 5600 nM
Beside the measured number, compound 3's estimate is 4.5-fold (0.65 log units) above it; measured number below the stated range.
By their numbers in this assay, from the lowest: compounds 3 and 1 (each within the scatter of the next); then compound 2.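

In this assay, exchanging hydroxymethyl for diacetoxymethyl on the double-bonded ring carbon gave an 11-fold lower number from compound 2 to compound 3 (1.02 log units; beyond the scatter), so the higher number of compound 2 does not extend to every oxygen-bearing group at this position. The much larger diacetoxymethyl group also leaves the number in range of the methyl group: a 1.8-fold lower number from compound 1 to compound 3 (0.25 log units; within the scatter) means that the two groups cannot be told apart in this assay. Thus, this position accepts diacetoxymethyl with no measurable loss relative to methyl.

The compounds shown leave open whether both acetoxy groups are needed, since a single acetoxymethyl group does not appear among them. Among the compounds shown here, they also leave open how an aldehyde, a carboxylic acid or an amine would fare here, and nothing measured so far accounts for the result.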